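Methylsulfanyl in place of the charged chain end

This account rests on a few compounds, and the source may have more. Where it says the series, first, only, none or still open, it means among the compounds named here.

In a functional assay (brain) for inhibition, with Rattus norvegicus as the target (on this read-out lower numbers stand for stronger inhibition and higher numbers for weaker inhibition), compound 3 `Cc1c(C)c2c(c(C)c1O)CCC(C)(CC[N+](C)(C)C)O2` gives 2600 nM and is second highest of the three numbers recorded so far. Its nearest neighbour is compound 1 `Cc1c(C)c2c(c(C)c1O)CC[C@@](C)(CC[N+](C)(C)C)O2`, which in this assay gives 2300 nM; the two differ only in that (the fact that one of compounds 1 and 3 is drawn with a defined configuration and the other without, at the place where they differ), and the step of a 1.1-fold higher number from compound 1 to compound 3 (0.05 log units; within the scatter) lies within the scatter. Furthest away is compound 2 `Cc1c(C)c2c(c(C)c1O)CC[C@@](C)(CC(=O)O)O2`, which in this assay gives 17000 nM.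

Compound 4 `CSCCC1(C)CCc2c(C)c(O)c(C)c(C)c2O1` has not yet been measured in this assay. It differs from compound 3 by a group of 2 heavy atoms (1 carbon, 1 sulfur; no ring) in place of a group of 4 heavy atoms (3 carbon, 1 nitrogen; no ring), on a saturated chain carbon, two bonds along the chain from a saturated ring carbon.

Going by the values given here, the one measured step that bears on this change is a 7.4-fold higher number from compound 1 to compound 2 (0.87 log units; beyond the scatter), where a neutral chain end also took the place of the charged one; that step was modest but beyond the scatter. The change to compound 4 likewise removes the charged chain end, so a step of similar size toward a higher number is expected, as a 3.5-fold higher number from compound 3 to compound 4 (0.54 log units; beyond the scatter).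

Compound 4 is therefore estimated at 9000 nM in this assay, with a range from 3000 nM to 27000 nM.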

Compound 4, half-maximal inhibitory concentration: 3000 nM
Compound 4: middle estimate off by 3.0-fold (0.48 log units), on the high side; low and high end bracket the measured number.
By their numbers in this assay, from the lowest: compounds 1, 3 and 4 (each within the scatter of the next); then compound 2.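

In this assay the change at this place gives a 1.2-fold higher number from compound 3 to compound 4 (0.06 log units; within the scatter), so methylsulfanyl, with no net charge, stands in for the charged chain end with a net charge of +1 and the number does not move beyond the scatter. A positive charge on a saturated chain carbon, two bonds along the chain from a saturated ring carbon, is thus not needed to hold the number in this range. The earlier 7.4-fold higher number from compound 1 to compound 2 (0.87 log units; beyond the scatter) can therefore not be read as the loss of the charged chain end alone.

Nothing at hand accounts for the flat step between these two chain ends. Open, on these data alone, is how an amine, a carboxylic acid or a longer chain would read on the chain of compound 4, and whether its single stereoisomers would match it.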